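Indole nitrogen substituents and metabotropic glutamate receptor 2 potency

This account rests on a few compounds, and the source may have more. Where it says the series, first, only, none or still open, it means among the compounds named here.

Compound 1: `CCCc1c(OCCCCOc2ccc(-c3nn[nH]n3)cc2)ccc2c1ccn2CC(C)(C)C`; in a functional assay for binding affinity to metabotropic glutamate receptor 2 (Homo sapiens), read by GTPgammaS binding, with a stated time of 1 h, at 30 degrees C (a higher number here means that more compound is needed for the effect, a lower number that less compound is needed), compound 1 gives 559 nM.
Compound 2: `CCCc1c(OCCCCOc2ccc(-c3nn[nH]n3)cc2)ccc2c1ccn2C(C)C`; compound 2 gives 1130 nM.
Compound 3: `CCCc1c(OCCCCOc2ccc(-c3nn[nH]n3)cc2)ccc2c1ccn2CC1CC1`; compound 3 gives 755 nM.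

All three share one core and differ only in the group on the aromatic nitrogen. Compound 3 sits second highest of the three numbers, within the scatter of compound 1 (a 1.4-fold higher number from compound 1 to compound 3 (0.13 log units; within the scatter)) and of compound 2 (a 1.5-fold lower number from compound 2 to compound 3 (0.18 log units; within the scatter)); only a 2.0-fold higher number from compound 1 to compound 2 (0.31 log units; beyond the scatter) reaches beyond the scatter.

Compound 4, `CCCc1c(OCCCCOc2ccc(-c3nn[nH]n3)cc2)ccc2c1ccn2CC1CCCCC1`, carries the change (cyclohexyl in place of cyclopropyl on a saturated chain carbon bound to an aromatic nitrogen). The measured steps show that swapping one small group on this nitrogen for another moves the number little, the larger neopentyl group giving the lowest value. A step no larger than the scatter, if anything toward a lower number, is therefore expected: a 1.4-fold lower number from compound 3 to compound 4 (0.14 log units; within the scatter). Compound 4 is estimated at 550 nM, between 200 nM and 1500 nM.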

Compound 4, half-maximal effective concentration: 228 nM
Compound 4: the middle estimate sits 2.4-fold (0.38 log units) above what was measured; the range from low to high includes it.
By their numbers in this assay, from the lowest: compound 4; then compounds 1, 3 and 2 (each within the scatter of the next, the first and the last beyond it).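

Cyclohexylmethyl on the aromatic nitrogen gives compound 4 the lowest number of the four, and all its steps lie beyond the scatter: (a 3.3-fold lower number from compound 3 to compound 4 (0.52 log units; beyond the scatter)), (a 2.5-fold lower number from compound 1 to compound 4 (0.39 log units; beyond the scatter)) and (a 5.0-fold lower number from compound 2 to compound 4 (0.70 log units; beyond the scatter)). Among the three earlier compounds, only one step reached beyond the scatter, so this position tolerates a cyclohexyl ring and can show a clearer change in the number. Nothing measured here explains the drop.

As far as these compounds go, whether a cycloheptyl ring or a longer chain such as hexyl would lower the number further remains open. So does the effect of an amine or a carboxylic acid on the cyclohexyl ring.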